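A few compounds are considered here, and "the series" means these few. Any claim that something is new, unique, unknown or untested is made for them only; others in the source may bear on it.

Measured compounds:
- compound 1 `COc1cc(-n2ncnc2-c2ccc(OC(C)C)cc2)cc(OC)c1OC`: 700 nM
- compound 2 `COc1cc(-c2ncnn2-c2cccc(N)c2)cc(OC)c1OC`: > 10000 nM
- compound 3 `COc1cc(-c2ncnn2-c2ccc(F)cc2)cc(OC)c1OC`: > 10000 nM

Among the compounds with values here, in a functional assay on HL-60 cells (Homo sapiens) for antiproliferative activity, read by MTT assay, with a stated time of 72 h (on this read-out higher numbers stand for weaker inhibition and lower numbers for stronger inhibition), compound 1 gives 700 nM, the only full number in the set. For compound 2 the result is a limit of the assay, > 10000 nM. For compound 3 the result is likewise a limit, > 10000 nM. Two of the three values therefore sit at the limit (the limit of > 10000 nM in this assay, at which 2 of the 3 values shown sit). Within the data shown here, the one measured step, a step that the two limits leave unreadable from compound 2 to compound 3, is unreadable and concerns a change on an aromatic nitrogen, so it says nothing about a change on an aromatic carbon.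

Compound 4 `COc1cc(-n2ncnc2-c2ccc(SC)cc2)cc(OC)c1OC` differs from compound 1 by methylsulfanyl in place of isopropoxy on an aromatic carbon. Among the measured compounds shown here, no measured step bears on this change; the expectation rests on compound 1 alone, at 700 nM, with a wide range to reflect the absence of any comparable pair. The expected step of a 1.2-fold lower number from compound 1 to compound 4 (0.07 log units; within the scatter) is taken as none beyond the scatter in this assay. Compound 4 is estimated at 600 nM, with a range from 150 nM to 3000 nM.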

Compound 4, half-maximal inhibitory concentration: 500 nM
Beside the measured number, compound 4's estimate is 1.2-fold (0.08 log units) above it, and the stated range covers the measured number.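

In this assay the series now has its first readable step, on an aromatic carbon of a six-membered aromatic ring of carbon only, para to a large group, and the change of isopropoxy to methylsulfanyl gives a 1.4-fold lower number from compound 1 to compound 4 (0.15 log units; within the scatter). This position therefore accepts either group with no change beyond the scatter, even though the entering methylsulfanyl has 2 heavy atoms against 4 in the leaving isopropoxy, and sulfur stands where oxygen stood. Nothing measured here bears on why the two groups read alike, as the only available observation concerns the limit reached by other compounds in the set.

Going by these compounds, two groups of this kind, each with no ring, no hydrogen-bond donor and 1 hydrogen-bond acceptor, mark out only a narrow part of what this position might accept, so the limits of that range remain open. An amine, a carboxylic acid or a longer chain such as butoxy on the same carbon would show whether the read-out stays where these two groups hold it, and plain hydrogen there would show whether the position needs a group at all.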